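Thiazolecarbonyl in Place of Pyridinylmethyl on the Ring Nitrogen

A few compounds are considered here, and "the series" means these few. Any claim that something is new, unique, unknown or untested is made for them only; others in the source may bear on it.

Compound 1 `CCCCNc1nc(N)nc2c1CCN(C(=O)c1ccccc1)C2` gives 0.8 uM in an assay on HEK293 cells for agonist activity at Toll-like receptor 8 (Homo sapiens), read by a luciferase reporter, with a stated time of 6 h; a higher number here means that more compound is needed for the effect, a lower number that less compound is needed. Compound 2 `CCCCNc1nc(N)nc2c1CN(Cc1ccc(-c3ccccc3)cc1)CC2` gives 0.5 uM in this assay. Compound 3 `CCCCNc1nc(N)nc2c1CN(Cc1ccccn1)CC2` gives 0.07 uM in this assay.

Among the three measured compounds, compound 3 stands at the lowest number, and its distance from both compound 2 and compound 1 lies beyond the usual scatter, so it is the most potent of the three on these numbers. The two compounds with a benzyl-type group or a benzoyl group sit well above it.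

Compound 4 `CCCCNc1nc(N)nc2c1CN(C(=O)c1csc(N)n1)CC2` differs from compound 3 in one place ((2-amino-1,3-thiazol-4-yl)carbonyl in place of (pyridin-2-yl)methyl on an amine nitrogen in a ring). Going by the values given here, no measured pair shows this exact change, so the step can only be judged from what compound 3 and the other two compounds show. Compound 1, which also carries a carbonyl-linked aromatic group on a ring nitrogen, gives 0.8 uM, a higher number than compound 3. On that basis the step is expected to move toward a higher number, by about a 5.7-fold higher number from compound 3 to compound 4 (0.76 log units; beyond the scatter), though with wide uncertainty given how few compounds are known. Compound 4 is therefore estimated at 0.4 uM, within a range from 0.08 uM to 2 uM.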

Compound 4, minimum effective concentration: 6.9 uM
Beside the measured number, compound 4's estimate is 17-fold (1.24 log units) below it; the measured number lies above the stated range.
By their numbers in this assay, from the lowest: compound 3; then compounds 2 and 1 (each within the scatter of the next); then compound 4.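

Going by these compounds alone, putting (2-amino-1,3-thiazol-4-yl)carbonyl in place of (pyridin-2-yl)methyl on the amine nitrogen in a ring gives a 99-fold higher number from compound 3 to compound 4 (1.99 log units; beyond the scatter) in this assay, the first direct reading of this position, and it shows that a single change there can cost a large part of the potency. Compound 1 also carries an aromatic group joined through a carbonyl, but it differs from compound 4 in more than one place, so its value says little about this step, and the carbonyl-linked aminothiazole of compound 4 has to be judged on its own. Nothing at hand accounts for the size of this step.

The step changes the link and the ring together, so the compounds shown do not separate the part played by the carbonyl from that of the aminothiazole ring. Going by these compounds, a (pyridin-2-yl)carbonyl group, a (2-amino-1,3-thiazol-4-yl)methyl group or a thiazolylcarbonyl group without the amino group on the same nitrogen would each divide the step, and which part of it they would recover remains open.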